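The compounds below may be only part of what the source reports. "The series", "measured", "known", "first", "only" and "open" are said of these compounds alone.

Among the measured compounds shown here, in a functional assay on LNCaP cells (Homo sapiens) for antiproliferative activity, read by WST assay, with a stated time of 3 days (on this read-out higher numbers stand for weaker inhibition and lower numbers for stronger inhibition), compound 1 `CCOc1c(-c2cc(OC)c(OC)c(OC)c2)oc2ccccc2c1=O` gives 5400 nM, while compound 2 `CCCCCOc1c(-c2cc(OC)c(OC)c(OC)c2)oc2ccccc2c1=O` gives 15400 nM, the higher of the two numbers so far. Compound 3 `CCCCCCOc1c(-c2cc(OC)c(OC)c(OC)c2)oc2ccccc2c1=O` differs from compound 2 by methyl in place of hydrogen on a saturated chain carbon, five bonds along the chain from an oxygen on an aromatic ring. For the measured compounds named here, the only measured step bearing on this change is a 2.9-fold higher number from compound 1 to compound 2 (0.46 log units; beyond the scatter), which came with propyl in place of hydrogen on the chain. For the smaller methyl addition, a small further rise in this assay is expected, possibly not beyond the scatter. The estimated step is a 1.2-fold higher number from compound 2 to compound 3 (0.09 log units; within the scatter). Compound 3 is estimated at 19000 nM, with an expected range from 9000 nM to 40000 nM.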

Compound 3, half-maximal inhibitory concentration: 19600 nM
Estimate against measurement, compound 3: 1.0-fold (0.01 log units) below; the measured number falls inside the stated range.
By their numbers in this assay, from the lowest: compound 1; then compounds 2 and 3 (each within the scatter of the next).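

In this assay, methyl in place of hydrogen five bonds along the chain from an oxygen on an aromatic ring gives a 1.3-fold higher number from compound 2 to compound 3 (0.10 log units; within the scatter) and so separates compound 2 from compound 3 by no more than the scatter. Butyl in place of hydrogen two bonds along the chain gives a 3.6-fold higher number from compound 1 to compound 3 (0.56 log units; beyond the scatter) and so shows that the weaker inhibition persists with this further extension. No available evidence bears on the reason for either step. As far as these compounds go, whether a methyl ether, a longer chain, or a chain ending in an amine or a carboxylic acid would differ from compound 1 remains open.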